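Triazolyl aryl methyl addition: compound 3 to compound 4

The source may report more compounds than this note shows. Statements on the series, on what has been measured and on what is new or still open speak of the compounds shown alone.

Three members of the series are measured in a functional assay on HCT-116 cells (Homo sapiens) for antiproliferative activity, read by MTT assay, with a stated time of 48 h; a lower number here means a stronger inhibitor, a higher number a weaker inhibitor. Compound 1 `Cc1ccc(-n2nncc2CN2C(=O)C3(C(C#N)=C(N)Oc4c3c3nc5ccccc5nc3c3ccccc43)c3ccccc32)cc1Cl` reaches only the limit of the assay, > 50000 nM. Compound 2 `N#CC1=C(N)Oc2c(c3nc4ccccc4nc3c3ccccc23)C12C(=O)N(Cc1cnnn1-c1cc(Cl)ccc1Cl)c1ccccc12` likewise returns the limit, > 50000 nM. Compound 3 `Cc1cccc(-n2nncc2CN2C(=O)C3(C(C#N)=C(N)Oc4c(N)cc5nc6ccccc6nc5c43)c3ccccc32)c1` returns the limit as well, > 50000 nM. The single one-point step among these three, a step that the two limits leave unreadable from compound 1 to compound 2, cannot be read in size. Compound 3 therefore stands nowhere in particular on the numbers shown: it holds only a limit, as do the two others, and the limit of > 50000 nM in this assay, at which 3 of the 3 values shown sit, is the whole of the evidence available on this assay.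

Compound 4 `Cc1cc(C)cc(-n2nncc2CN2C(=O)C3(C(C#N)=C(N)Oc4c(N)cc5nc6ccccc6nc5c43)c3ccccc32)c1` is the next member. The change from compound 3 is methyl in place of hydrogen on an aromatic carbon. Going by the values given here, no measured step touches a change of this kind; the only step recorded is unreadable. Nothing shown supports an expectation of movement in either direction in this assay, and the expectation for compound 4 is that it remains at the limit. For compound 4 the estimate is 80000 nM, with a range from 30000 nM to 250000 nM. The step that this estimate implies, a step that the limit leaves unreadable from compound 3 to compound 4, is expected to be nothing beyond the scatter.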

Compound 4, half-maximal inhibitory concentration: > 50000 nM
Compound 4 was reported as a limit; the forecaster's own chance of this, stated with the estimate: 85%; the middle value lies beyond the limit too.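

In this assay compound 4 gives > 50000 nM, which is a limit and not a number. Compound 3 also holds only a limit, so the step between compound 3 and compound 4 cannot be read. The compounds shown leave open whether any change to the shared core or its aryl group gives a measurable value: the limit of > 50000 nM in this assay, at which 4 of the 4 values shown sit.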